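The compounds below may be only part of what the source reports. "The series", "measured", "known", "first", "only" and "open" are said of these compounds alone.

Measured so far:
Compound 1, `CSc1ccc2c(c1)c(O)c(C(=O)N(C)c1ccccc1)c(=O)n2C` — 67%
Compound 2, `CSc1ccc2c(c1)c(O)c(C(=S)N(C)c1ccccc1)c(=O)n2C` — 32%

In a functional assay on the whole organism for inhibition, with Mus musculus as the target, at a dose of 10 mg/kg by the oral route (on this read-out higher numbers stand for more inhibition at the one dose given (going by the name of the read-out) and lower numbers for less inhibition), compound 1 gives 67%, while compound 2 gives 32%. Within the data shown here, no step between these two is set out here, so only the two values themselves can be compared: compound 2 stands lowest of the two numbers, and its nearest neighbour, compound 1, sits higher by a gap that goes beyond the usual scatter.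

Compound 3, `COc1ccc2c(c1)c(O)c(C(=S)N(C)c1ccccc1)c(=O)n2C`, is not yet measured. It differs from compound 2 in one place: methoxy in place of methylsulfanyl on an aromatic carbon. Among the measured compounds shown here, no measured pair shows this kind of change, so nothing in the numbers says how large its effect should be. The expected step from compound 2 to compound 3 in this assay is therefore small, a number 3 percentage points higher from compound 2 to compound 3 (within the scatter), and none beyond the scatter. Compound 3 is estimated at 35%, in a range from 10% to 60%.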

Compound 3, a percentage reported as inhibition, in the whole organism at one dose (the size of the read-out at that dose, not a potency): 31%
Estimate against measurement, compound 3: 4 percentage points above, and the stated range covers the measured number.
By their numbers in this assay, from the lowest: compounds 3 and 2 (each within the scatter of the next); then compound 1.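

Replacing methylsulfanyl with methoxy on this aromatic carbon gives, in this assay, a number 1 percentage points lower from compound 2 to compound 3 (within the scatter). This is the first measured change at this position, and it shows that with the rest of compound 2 kept, this read-out does not tell these two groups apart, so the sulfur of methylsulfanyl is not shown to matter here. Nothing measured on hand speaks to why the two groups read alike.

As far as these compounds go, whether the same swap would read the same way on the core of compound 1 stays open. From the compounds shown here alone, it is also open what a group of another kind would do on this aromatic carbon, such as an amine, a carboxylic acid or a longer chain in place of the methoxy.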